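A chloro swap in a compound with only a limit

A few compounds are considered here, and "the series" means these few. Any claim that something is new, unique, unknown or untested is made for them only; others in the source may bear on it.

In a functional assay (Homo sapiens) for cytotoxicity (on this read-out higher numbers stand for weaker inhibition and lower numbers for stronger inhibition), compound 1 `O=c1ccn(COCCO)c(=O)[nH]1` gives > 100000 nM, which is a limit and not a number. Compound 2 `Cc1c([Se]c2ccccc2)n(COCCO)c(=O)[nH]c1=O` gives > 200000 nM, also a limit, so compound 2 has no exact value. Compound 3 `O=c1[nH]c(=O)n(COCCO)c([Se]c2ccccc2)c1Cl` carries chloro in place of methyl on an aromatic carbon. Among the measured compounds shown here, no measured pair of compounds shows what such a swap does, so no change beyond the usual scatter is expected. The expected step is a number no higher from compound 2 to compound 3 (the limit leaves the size open). For compound 3, the estimated value is 200000 nM, within an expected range of 80000 nM to 400000 nM.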

Compound 3, half-maximal inhibitory concentration: > 100000 nM
Compound 3 was reported as a limit; the forecaster's own chance of this, stated with the estimate: 75%; the middle value does not contradict the limit.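

Among the compounds shown here, compound 2 and compound 3 are each reported only as a limit and not as a number, so no step between them can be read. On these data alone, whether chloro in place of methyl on an aromatic carbon changes the read-out at all stays open.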